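Amino in place of bromo: compound 2 to compound 3

The compounds below may be only part of what the source reports. "The series", "measured", "known", "first", "only" and "open" are said of these compounds alone.

compound 1 `Fc1cccc(-c2nc(Nc3cccc(Cl)c3)c3cc(F)ccc3n2)c1` — a functional assay on MDA-MB-231 cells (Homo sapiens) for cytotoxicity, read by MTT assay, with a stated time of 48 h; on this read-out higher numbers stand for weaker inhibition and lower numbers for stronger inhibition: > 50000 nM
compound 2 `Fc1cccc(-c2nc(Nc3ccccc3Br)c3cc(F)ccc3n2)c1` — this assay: > 50000 nM

Compound 2 gives only a limit in this assay, not a number. The same holds for compound 1, so that (the limit of > 50000 nM in this assay, at which 2 of the 2 values shown sit). The step that the two limits leave unreadable from compound 1 to compound 2 is therefore unreadable and offers no measured size to carry forward.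

Compound 3 `Nc1ccccc1Nc1nc(-c2cccc(F)c2)nc2ccc(F)cc12` differs from compound 2 by amino in place of bromo on an aromatic carbon. Among the compounds with values here, no measured step on this core bears on that change, so no direction is supported beyond the scatter. Compound 3 is expected to remain near the limit, an estimated step of an at least 1.1-fold lower number from compound 2 to compound 3 (0.04 log units; that floor lies within the scatter). The estimate for compound 3 in this assay is 45000 nM, within 12000 nM to 150000 nM.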

Compound 3, half-maximal inhibitory concentration: > 50000 nM
Compound 3 was reported as a limit; the forecaster's own chance of this, stated with the estimate: 65%; middle value at least 1.1-fold (0.04 log units) from the limit.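

Compound 3, like compound 1 and compound 2, gives only a limit, so no step among the three can be read: the limit of > 50000 nM in this assay, at which 3 of the 3 values shown sit.

As far as these compounds go, how 2-aminophenyl, 2-bromophenyl and 3-chlorophenyl compare on the shared core stays open, as does which change would give a measurable value.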